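The source may report more compounds than this note shows. Statements on the series, on what has been measured and on what is new or still open speak of the compounds shown alone.

Measured compounds:
compound 1, `N=C(NCc1ccc(O)cc1)[C@@H]1CCC(=O)N1Cc1ccc([N+](=O)[O-])cc1`, 25.9% in this assay
compound 2, `COc1ccc(CNC(=N)[C@@H]2CCC(=O)N2Cc2ccc([N+](=O)[O-])cc2)cc1`, 14.3%
compound 3, `N=C(NCc1ccc(O)cc1)[C@@H]1CCC(=O)N1Cc1ccc(F)cc1`, 35.2%

All three were run in a functional assay on SH-SY5Y cells (Homo sapiens) for cytotoxicity, read by MTT assay, with stated times of 8 h, 30 min and 12 h, tested at 0.05 uM; a higher number here means a stronger effect of the compound at the concentration tested, a lower number a weaker effect. Compound 1 and compound 2 share one core and differ only by methyl in place of hydrogen on an oxygen on an aromatic ring; this change gives a number 11.6 percentage points lower from compound 1 to compound 2 (beyond the scatter). Compound 1 and compound 3 differ by fluoro in place of nitro on an aromatic carbon, which gives a number 9.3 percentage points higher from compound 1 to compound 3 (within the scatter), so the values of compound 1 and compound 3 cannot be told apart. Compound 2 and compound 3 were not compared as a single step; their values simply stand apart from each other.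

Compound 4, `COc1ccc(CNC(=N)[C@@H]2CCC(=O)N2Cc2ccc(F)cc2)cc1`, has not yet been measured in this assay. It differs from compound 3 by methyl in place of hydrogen on an oxygen on an aromatic ring, the same change already seen once between compound 1 and compound 2, at the same place. The cores of compound 3 and compound 4 differ from those of compound 1 and compound 2 by fluoro in place of nitro on an aromatic carbon.

For the measured compounds named here, on the one earlier instance of this change, a drop of about a number 11.2 percentage points lower from compound 3 to compound 4 (beyond the scatter) is expected, resting on a number 11.6 percentage points lower from compound 1 to compound 2 (beyond the scatter) from compound 1 to compound 2. Compound 4 is therefore estimated at 24%, most likely between 12% and 36%.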

Compound 4, a percentage reported as activity, at one concentration (the size of the read-out at that concentration, not a potency): 15.8%
Compound 4: middle estimate off by 8.2 percentage points, on the high side; low and high end bracket the measured number.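

In this assay, hydroxy to methoxy again brings a clear drop on the fluoro core, a number 19.4 percentage points lower from compound 3 to compound 4 (beyond the scatter), and the size of this step carries over from the nitro core without a difference that can be read: the same change on two cores in this assay, a number 11.6 percentage points lower (beyond the scatter) from compound 1 to compound 2 and a number 19.4 percentage points lower (beyond the scatter) from compound 3 to compound 4, 7.8 percentage points apart, within the scatter of two such steps. Fluoro in place of nitro, now read on the methoxy core as a number 1.5 percentage points higher from compound 2 to compound 4 (within the scatter), leaves the two compounds indistinguishable, as it did on the hydroxy core: the same change on two cores in this assay, a number 9.3 percentage points higher (within the scatter) from compound 1 to compound 3 and a number 1.5 percentage points higher (within the scatter) from compound 2 to compound 4, 7.8 percentage points apart, within the scatter of two such steps. For the compounds shown here, this shows that both changes behaved consistently across the four compounds, but it rests on only two cores and one concentration, so it does not show that the steps are identical or that they would carry over to a core outside this set.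

The compounds shown carry only hydroxy or methoxy on one aromatic ring and only nitro or fluoro on the other. Going by these compounds, whether a longer chain on that oxygen, such as ethoxy, or an amine or chloro in place of the nitro or fluoro group would follow the same steps remains open.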